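The source may hold more compounds than are shown below. What is called first, only, known or untested is meant among the compounds shown, and "the series" means these compounds.

Compound 2 `C=CCc1cc(C(C)=O)c(O)cc1OCCCCCCCC#N` gives 52% in an assay on isolated protein for binding affinity to leukotriene B4 receptor 1 (Homo sapiens), tested at 1 uM (on this read-out lower numbers stand for less inhibition and higher numbers for more inhibition at the one concentration tested (going by the name of the read-out)), the lowest of the three numbers: compound 1 `CCc1cc(C(C)=O)c(O)cc1OCCCCCCC#N` gives 73% and compound 3 `CCc1cc(C(C)=O)c(O)cc1OCCCC(C)(C)c1nnn[nH]1` gives 76%, each beyond the scatter above compound 2. Compound 4 `C=CCc1cc(C(C)=O)c(O)cc1OCCCCCC(=O)NO` differs from compound 2 by hydroxycarbamoyl in place of 2-cyanoethyl on a saturated chain carbon, five bonds along the chain from an oxygen on an aromatic ring. Among the measured compounds shown here, the only measured step that exchanges a cyano-ended chain for a different terminal group is a number 3 percentage points higher from compound 1 to compound 3 (within the scatter), which stayed within the scatter. On that evidence compound 4 is expected to move by a number 3 percentage points higher from compound 2 to compound 4 (within the scatter), no step beyond the scatter in this assay. Compound 4 is therefore estimated at 55%, within a range from 35% to 75%.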

Compound 4, a percentage reported as inhibition, at one concentration (the size of the read-out at that concentration, not a potency): 28%
Beside the measured number, compound 4's estimate is 27 percentage points above it; measured number below the stated range.
By their numbers in this assay, from the lowest: compound 4; then compound 2; then compounds 1 and 3 (each within the scatter of the next).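

In this assay, the end of this chain proves sensitive to what is placed there: hydroxycarbamoyl in place of 2-cyanoethyl gives a number 24 percentage points lower from compound 2 to compound 4 (beyond the scatter) and so lies beyond the scatter. The one earlier exchange of a nitrile end, a number 3 percentage points higher from compound 1 to compound 3 (within the scatter), had shown no such loss, so that result does not carry over to every replacement. Nothing available accounts for the drop.

On these data alone, whether the loss belongs to hydroxycarbamoyl itself stays open. A carboxylic acid or a primary amide at this position, or hydroxycarbamoyl on a longer chain, would help to settle that.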